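A few compounds are considered here, and "the series" means these few. Any claim that something is new, unique, unknown or untested is made for them only; others in the source may bear on it.

Working notes on the sulfonyl series. Compound 1 `Cc1ccc(S(=O)(=O)c2n[nH]c3ccc(N4CCN(C)CC4)cc23)cc1` gives 112 nM in a functional assay on HeLa cells for antagonist activity at 5-hydroxytryptamine receptor 6 (Homo sapiens); on this read-out higher numbers stand for weaker inhibition and lower numbers for stronger inhibition. Compound 2 `CN1CCN(c2ccc3[nH]nc(S(=O)(=O)c4ccccc4Cl)c3c2)CC1` gives 101 nM in this assay. Compound 3 `COc1cccc(S(=O)(=O)c2n[nH]c3ccc(N4CCN(C)CC4)cc23)c1` gives 57 nM in this assay. Compound 3 stands at the smallest of the three numbers, though its gaps to compound 1 and to compound 2 both lie within the scatter. Compound 4 `CN1CCN(c2ccc3[nH]nc(S(=O)(=O)c4c(Cl)cccc4Cl)c3c2)CC1` differs from compound 3 by 2,6-dichlorophenyl in place of 3-methoxyphenyl on a sulfonyl sulfur. The comparable aryl swaps on the sulfonyl sulfur measured so far, a 1.1-fold lower number from compound 1 to compound 2 (0.04 log units; within the scatter), a 2.0-fold lower number from compound 1 to compound 3 (0.29 log units; within the scatter) and a 1.8-fold lower number from compound 2 to compound 3 (0.25 log units; within the scatter), all stayed within the scatter, so no step beyond the scatter is expected in either direction. Compound 4 is accordingly estimated at 95 nM, with a range of 35 nM to 280 nM. The expected step is a 1.7-fold higher number from compound 3 to compound 4 (0.22 log units; within the scatter).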

Compound 4, half-maximal inhibitory concentration: 40 nM
Estimate against measurement, compound 4: 2.4-fold (0.38 log units) above; low and high end bracket the measured number.
By their numbers in this assay, from the lowest: compounds 4, 3, 2 and 1 (each within the scatter of the next, the first and the last beyond it).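

Going by these compounds alone, on the sulfonyl sulfur, 2,6-dichlorophenyl gives the first steps beyond the scatter: a 2.5-fold lower number from compound 2 to compound 4 (0.40 log units; beyond the scatter), where chloro replaces hydrogen on an aromatic carbon, and a 2.8-fold lower number from compound 1 to compound 4 (0.45 log units; beyond the scatter), both modest. Against 3-methoxyphenyl there is no separation, with a 1.4-fold lower number from compound 3 to compound 4 (0.15 log units; within the scatter). No measurement at hand accounts for these steps.

Still open, from the compounds shown here alone, is how an amine or a carboxylic acid on the aryl ring, or a benzyl group on the sulfonyl sulfur, would read in this assay. Also open, going by these compounds, is whether fluoro in place of the added chloro would give a comparable step.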